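The compounds below may be only part of what the source reports. "The series", "measured", "known", "first", "only" and "open" are said of these compounds alone.

In an ADME assay on L6 cells (Rattus norvegicus) for cytotoxicity, read by resazurin assay, with a stated time of 72 h (on this read-out higher numbers stand for weaker inhibition and lower numbers for stronger inhibition), compound 1 (`OC(c1ccc(Cl)cc1)(c1ccc(Br)cc1)c1cccnc1`) gives 57000 nM and compound 2 (`OC(c1ccc(Cl)cc1)(c1cccnc1)c1ccc(Cl)cc1F`) sits close by with 59400 nM as its number. Compound 3 (`OC(c1ccc(Cl)cc1)(c1cccnc1)c1ccc(F)cc1F`) has 70200 nM as its number, which places it level with both of the others, since its gaps to them lie within the usual scatter of repeat measurements. The three compounds therefore cannot be ranked on these numbers.

Compound 4 (`OC(c1ccc(Cl)cc1)(c1cccnc1)c1ccc(Br)cc1F`) differs from compound 3 at a single place bromo in place of fluoro on an aromatic carbon and carries bromo in place of fluoro on an aromatic carbon. The most relevant measured step involves that same carbon. There, fluoro in place of chloro gave a 1.2-fold higher number from compound 2 to compound 3 (0.07 log units; within the scatter) and so made no difference beyond the scatter. Compound 1 also carries a bromo group, and it too lies within the scatter of compound 2 and compound 3. Swapping one halogen for another has thus shown no clear effect in these few compounds, although bromo at this carbon alongside the fluoro group remains unmeasured.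

No step beyond the scatter is expected, and the estimated change is a 1.2-fold lower number from compound 3 to compound 4 (0.08 log units; within the scatter) for now. For compound 4 the expected value is 58000 nM (estimated range 35000 nM to 95000 nM).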

Compound 4, half-maximal inhibitory concentration: 79200 nM
Compound 4: the middle estimate sits 1.4-fold (0.14 log units) below what was measured; the range from low to high includes it.
By their numbers in this assay, from the lowest: compounds 1, 2, 3 and 4 (each within the scatter of the next).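

This position now has three halogens to compare. In this assay, within the data shown here, bromo in place of fluoro gives a 1.1-fold higher number from compound 3 to compound 4 (0.05 log units; within the scatter), and bromo in place of chloro gives a 1.3-fold higher number from compound 2 to compound 4 (0.12 log units; within the scatter), so chloro, fluoro and bromo on this carbon all read the same within the scatter, even though the earlier compounds had compared only chloro and fluoro here. The second change, the addition of a fluoro group with bromo already in place, gives a 1.4-fold higher number from compound 1 to compound 4 (0.14 log units; within the scatter) and also stays inside the scatter, so in these four compounds neither swap separates one compound from another. No measured evidence is available to explain this flat result.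

Every compound shown has a halogen on this carbon, which leaves open whether a quite different group, such as an amine, a carboxylic acid or a longer chain, would move the number beyond the scatter. On these data alone, it is also open whether changes elsewhere on the shared core would stay as flat as these halogen swaps have.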